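The compounds below may be only part of what the source reports. "The series", "measured", "known", "first", "only" and "open" are said of these compounds alone.

Of the compounds shown here, two with a shared core have been tested in an ADME assay on MT4 cells (Homo sapiens) for cytotoxicity, read by MTT assay; on this read-out lower numbers stand for higher toxicity in this test and higher numbers for lower toxicity in this test. Compound 1, `CCOC(=O)/C(O)=C/C(=O)c1cn(Cc2c(F)ccc(F)c2F)c2cccc(OC)c12`, gives 40500 nM in this assay. Compound 2, `COc1cccc2c1c(C(=O)/C=C(\O)C(=O)O)cn2Cc1ccc(F)cc1`, gives 41100 nM. These two numbers sit within the usual scatter of each other, so compound 1 stands level with compound 2 rather than apart from it, and both point to low toxicity toward these cells. Compound 3, `CCOC(=O)/C(O)=C/C(=O)c1cn(Cc2cc(F)cc(F)c2)c2cccc(OC)c12`, has not yet been measured. It differs from compound 1 in one place: 3,5-difluorophenyl in place of 2,3,6-trifluorophenyl on a saturated chain carbon bound to an aromatic nitrogen. Within the data shown here, no measured pair shows what such a change does here, and the two measured compounds give numbers within the scatter of each other, so only a small step is expected, a 1.0-fold lower number from compound 1 to compound 3 (0.01 log units; within the scatter), with nothing beyond the scatter in either direction. Compound 3 is therefore estimated at 40000 nM, within a range from 18000 nM to 90000 nM.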

Compound 3, half-maximal cytotoxic concentration: 34700 nM
For compound 3 the middle estimate is 1.2-fold (0.06 log units) above the measured one; the measured number falls inside the stated range.
By their numbers in this assay, from the lowest: compounds 3, 1 and 2 (each within the scatter of the next).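

Among these compounds, this pair gives the first direct reading of a change on the saturated chain carbon bound to an aromatic nitrogen: putting 3,5-difluorophenyl in place of 2,3,6-trifluorophenyl gives a 1.2-fold lower number from compound 1 to compound 3 (0.07 log units; within the scatter) in this assay on the shared core. So in this pair, losing one fluorine and placing the remaining two differently leaves the read-out within the scatter, and the two compounds cannot be told apart in this test. No measurement shown here offers an explanation for this result.

From the compounds shown here alone, it remains open whether a group of a different kind at this place, such as an amine or a longer chain, would move the number beyond the scatter. Also open, going by these compounds, is whether a phenyl ring carrying no fluorine would do so.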